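The source may hold more compounds than are shown below. What is called first, only, known or untested is meant among the compounds shown, and "the series" means these compounds.

Measured so far in a functional assay on MGC-803 cells (Homo sapiens) for inhibition, read by MTT assay, with a stated time of 72 h; on this read-out lower numbers stand for stronger inhibition and higher numbers for weaker inhibition: compound 1 `O=C(/C=C/c1ccc(Oc2ncnc3ccc(Cl)cc23)cc1)/C=C/c1cc([N+](=O)[O-])ccc1Cl` gives 2150 nM; compound 2 `O=C(/C=C/c1ccc(Oc2ncnc3ccc(Cl)cc23)cc1)/C=C/c1ccc(Cl)c([N+](=O)[O-])c1` gives 7190 nM; compound 3 `O=C(/C=C/c1ccc(Cl)c(Cl)c1)/C=C/c1ccccc1Oc1ncnc2ccc(Cl)cc12` gives 16200 nM.

Compound 2 stands second highest of the three numbers: compound 3 sits above it, compound 1 below it, both separations beyond the scatter. The step of a 3.3-fold higher number from compound 1 to compound 2 (0.52 log units; beyond the scatter) is the only one measured within the shared core of compound 2 and it merely moves the same two groups around the ring. The change to compound 4 `O=C(/C=C/c1ccc(Oc2ncnc3ccc(Cl)cc23)cc1)/C=C/c1cccc(Cl)c1Cl` is 2,3-dichlorophenyl in place of 4-chloro-3-nitrophenyl on a double-bonded chain carbon bound to a double-bonded chain carbon. Among the measured compounds shown here, no measured step exchanges a nitro group for chlorine on this core, so no direction can be read off. Compound 3 carries two chlorines on its chain-bound ring but a differently placed ether, and its number is the highest shown. Compound 4 is therefore expected near compound 2, step a 1.2-fold lower number from compound 2 to compound 4 (0.08 log units; within the scatter), estimate 6000 nM with range 1800 nM to 20000 nM.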

Compound 4, half-maximal inhibitory concentration: 7300 nM
Compound 4: middle estimate off by 1.2-fold (0.09 log units), on the low side, and the stated range covers the measured number.
By their numbers in this assay, from the lowest: compound 1; then compounds 2 and 4 (each within the scatter of the next); then compound 3.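

In this assay, the step of a 1.0-fold higher number from compound 2 to compound 4 (0.01 log units; within the scatter) shows that 2,3-dichlorophenyl and 4-chloro-3-nitrophenyl cannot be told apart on a double-bonded chain carbon bound to a double-bonded chain carbon. With a 3.4-fold higher number from compound 1 to compound 4 (0.53 log units; beyond the scatter), the 2-chloro-5-nitrophenyl group stands apart from both, so the presence of a nitro group alone does not set the number on this core. Nothing available explains these results.

From the compounds shown here alone, it remains open how a phenyl ring carrying an amine or a carboxylic acid would read at this position.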